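This account rests on a few compounds, and the source may have more. Where it says the series, first, only, none or still open, it means among the compounds named here.

Compound 3 `COc1cc(/C=N/Nc2nc(-c3cccc(Br)c3)cs2)cc(Br)c1OC` belongs to a small set of compounds tested in a functional assay on A549 cells (Homo sapiens) for inhibition, read by MTT assay, with a stated time of 48 h (on this read-out lower numbers stand for stronger inhibition and higher numbers for weaker inhibition), where compound 3 gives 56000 nM. Among the compounds with values here, that is the highest of the three numbers known so far. Compound 2 `COc1cc(/C=N/Nc2nc(-c3ccc(Br)cc3)cs2)cc(Br)c1OC` gives 52300 nM, a number so close to that of compound 3 that the two cannot be told apart, while compound 1 `Fc1ccc(/C=N/Nc2nc(-c3cc(C(F)(F)F)cc(C(F)(F)F)c3)cs2)cc1F` gives 6230 nM, the lowest of the three. Within the data shown here, the only step between measured compounds that changes one place is a 1.1-fold higher number from compound 2 to compound 3 (0.03 log units; within the scatter), a change in where the bromine sits on the ring. Compound 4 `COc1cc(/C=N/Nc2nc(-c3ccc(F)c(F)c3)cs2)cc(Br)c1OC` differs from compound 3 by 3,4-difluorophenyl in place of 3-bromophenyl on an aromatic carbon. Among the measured compounds shown here, no measured step swaps this ring for a fluorinated one, so nothing measured bears directly on the exchange. Because a 1.1-fold higher number from compound 2 to compound 3 (0.03 log units; within the scatter) was a step within the scatter, a step of similar size is the most that the data support for compound 4 in this assay. Compound 4 is therefore expected to give 40000 nM, an expected step of a 1.4-fold lower number from compound 3 to compound 4 (0.15 log units; within the scatter), with a likely range from 12000 nM to 130000 nM.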

Compound 4, half-maximal inhibitory concentration: 21100 nM
The estimate for compound 4 lay 1.9-fold (0.28 log units) above the measured number; measured number inside the range.
By their numbers in this assay, from the lowest: compound 1; then compound 4; then compounds 2 and 3 (each within the scatter of the next).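

Moving the bromine around the ring earlier left the number unchanged within the scatter, but replacing the bromophenyl group at this position, on the aromatic carbon next to the ring nitrogen, does shift it in this assay. The change gives a 2.7-fold lower number from compound 3 to compound 4 (0.42 log units; beyond the scatter) and, starting from the other bromine isomer, a 2.5-fold lower number from compound 2 to compound 4 (0.39 log units; beyond the scatter), so both bromophenyl compounds move the same way by a modest amount. Nothing available explains why this exchange lowers the number.

The compounds shown cannot separate the effect of losing the bromine from that of adding the fluorines, as both happen in one step. From the compounds shown here alone, how this position would respond to a plain phenyl, a 4-fluorophenyl, or a phenyl ring carrying an amine or a carboxylic acid also remains open.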